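Moving fluorine from 2-fluorophenyl to 4-fluorophenyl

This account rests on a few compounds, and the source may have more. Where it says the series, first, only, none or still open, it means among the compounds named here.

For the measured compounds named here, in a functional assay on B16 cells (Mus musculus) for antiproliferative activity, read by MTT assay, with a stated time of 24 h (a higher number here means a weaker inhibitor, a lower number a stronger inhibitor), compound 1 `C=CCOc1ccc2c(=O)c(-c3cc(OC)c(OC)cc3OC)coc2c1` gives 5100 nM and compound 2 `COc1cc(OC)c(-c2coc3cc(OCc4ccccc4F)ccc3c2=O)cc1OC` gives 1610 nM as the lower of the two numbers so far. Compound 3 `COc1cc(OC)c(-c2coc3cc(OCc4ccc(F)cc4)ccc3c2=O)cc1OC` has 4-fluorophenyl in place of 2-fluorophenyl on a saturated chain carbon bound to an oxygen on an aromatic ring with the same atoms joined differently. Going by the values given here, the only measured step of a 3.2-fold lower number from compound 1 to compound 2 (0.50 log units; beyond the scatter) is modest, but it swaps vinyl for 2-fluorophenyl and does not compare the two fluorophenyl groups. No change beyond the scatter is therefore expected in this assay and no direction is favoured. The expected step is a 1.1-fold higher number from compound 2 to compound 3 (0.02 log units; within the scatter) in this estimate. Compound 3 is expected at 1700 nM within an estimated range from 700 nM to 4000 nM for now.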

Compound 3, half-maximal inhibitory concentration: 1120 nM
Compound 3: middle estimate off by 1.5-fold (0.18 log units), on the high side, and the stated range covers the measured number.
By their numbers in this assay, from the lowest: compounds 3 and 2 (each within the scatter of the next); then compound 1.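

In this assay, the fluorine swap on a saturated chain carbon bound to an oxygen on an aromatic ring gives a 1.4-fold lower number from compound 2 to compound 3 (0.16 log units; within the scatter), so these data do not separate 2-fluorophenyl from 4-fluorophenyl. Replacing vinyl with 4-fluorophenyl gives a 4.6-fold lower number from compound 1 to compound 3 (0.66 log units; beyond the scatter), so the lower number first seen with 2-fluorophenyl also holds for the second fluorophenyl group. No available evidence explains either step.

It remains open whether fluorine matters at all, as phenyl without fluorine is not among these compounds. From the compounds shown here alone, the effect of an amine or a carboxylic acid on the ring at this position is also open.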